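Capping the Chain Amine of Compound 2

The source may report more compounds than this note shows. Statements on the series, on what has been measured and on what is new or still open speak of the compounds shown alone.

Within the data shown here, compound 2 `COC(=O)CC1c2ccccc2N=C(NCCCCCN)N1c1ccc(-c2ccccc2)cc1` gives 97% in an assay on cells (Oocyte) for inhibition of Voltage-dependent T-type calcium channel subunit alpha-1H (Homo sapiens), tested at 100 uM (a lower number here means less inhibition, a higher number more inhibition at the concentration tested (going by the name of the read-out)), the higher of the two numbers measured so far. Among the measured compounds shown here, its nearest neighbour, compound 1 `NCCCCCNC1=Nc2ccccc2C(CC(=O)NCc2ccccc2)N1c1ccc(-c2ccccc2)cc1`, gives 80.1% in this assay; the one measured step between them, a number 16.9 percentage points higher from compound 1 to compound 2 (beyond the scatter), turned on a methoxy in place of benzylamino on a carbonyl carbon. Compound 3 `COC(=O)CC1c2ccccc2N=C(NCCCCCNC(=O)OC(C)(C)C)N1c1ccc(-c2ccccc2)cc1` has not yet been measured. It differs from compound 2 only at the end of the chain: tert-butoxycarbonyl in place of hydrogen on an amine nitrogen. For the measured compounds named here, no measured step touches this amine nitrogen; the step from compound 1 to compound 2 changed a different part of the molecule and so gives no guide to what a tert-butoxycarbonyl in place of hydrogen will do. With nothing measured on this position, and compound 2 already near the top of the scale, the expectation is a modest fall at most, a number 12 percentage points lower from compound 2 to compound 3 (beyond the scatter), with a wide range around it. Compound 3 is therefore estimated at 85% in this assay, expected to lie between 60% and 100%.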

Compound 3, a percentage reported as inhibition, at one concentration (the size of the read-out at that concentration, not a potency): 92.2%
Compound 3: the middle estimate sits 7.2 percentage points below what was measured; measured number inside the range.
By their numbers in this assay, from the lowest: compound 1; then compounds 3 and 2 (each within the scatter of the next).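

In this assay the change at the chain end reads a number 4.8 percentage points lower from compound 2 to compound 3 (within the scatter) and this gives the amine nitrogen its first measured step, one that the earlier comparison of compound 1 and compound 2 could not supply. Replacing hydrogen with tert-butoxycarbonyl adds 7 heavy atoms at the end of the chain, yet the two readings cannot be told apart. For this pair, then, a bare amine at the chain end is not needed to reach this level of inhibition at the concentration tested. Nothing available explains this result.

Both compounds read close to the top of the scale at a single concentration, and such a reading does not show how potent either one is, so a real difference between them could remain hidden. On these data alone, it also remains open whether a smaller acetyl group on the same nitrogen, a carboxylic acid in place of the amine, or a longer chain would give a similar reading.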